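The source may report more compounds than this note shows. Statements on the series, on what has been measured and on what is new or still open speak of the compounds shown alone.

Of the compounds shown here, two of a shared core have been measured in a functional assay on HEK293 cells for antagonist activity at Voltage-dependent L-type calcium channel subunit alpha-1D (Rattus norvegicus), read by FLIPR; a lower number here means a stronger inhibitor, a higher number a weaker inhibitor. Compound 1 `CCOC(=O)C1=C(C)NC(COC(C)=O)=C(C(=O)OCC)C1c1cccc([N+](=O)[O-])c1` gives 37 nM, whereas compound 2 `CCOC(=O)C1=C(C)NC(C(OCC)OCC)=C(C(=O)OCC)C1c1cccc([N+](=O)[O-])c1` gives 615 nM. Compound 2 thus stands at the highest of the two numbers, its nearest neighbour being compound 1, which lies a 17-fold higher number from compound 1 to compound 2 (1.22 log units; beyond the scatter) away.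

The next step leads to compound 3 `CCOC(=O)C1=C(C)NC(/C=C/c2ccc([N+](=O)[O-])cc2)=C(C(=O)OCC)C1c1cccc([N+](=O)[O-])c1`. It differs from compound 2 by 2-(4-nitrophenyl)ethenyl in place of diethoxymethyl on a double-bonded ring carbon. Among the compounds with values here, only one measured step bears on this position: the change from compound 1 to compound 2 gave a 17-fold higher number from compound 1 to compound 2 (1.22 log units; beyond the scatter), which shows that the group on this carbon moves the number strongly in this assay. Within the data shown here, no measured step, however, shows what a 2-(4-nitrophenyl)ethenyl group does there, so the direction can be inferred only loosely: the one exchange observed at this position took the number up, and the new group is not the one that gave that high number. Compound 3 is therefore expected to give a lower number than compound 2, by about a 4.1-fold lower number from compound 2 to compound 3 (0.61 log units; beyond the scatter), with wide uncertainty. The estimate for compound 3 in this assay is 150 nM, between 30 nM and 1500 nM.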

Compound 3, half-maximal inhibitory concentration: 2060 nM
For compound 3 the middle estimate is 14-fold (1.14 log units) below the measured one; the whole stated range lies below it.
By their numbers in this assay, from the lowest: compound 1; then compound 2; then compound 3.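

In this assay, the 2-(4-nitrophenyl)ethenyl group on this double-bonded ring carbon gives a 3.3-fold higher number from compound 2 to compound 3 (0.52 log units; beyond the scatter), and, set against the acetoxymethyl group, a 56-fold higher number from compound 1 to compound 3 (1.75 log units; beyond the scatter). Within the data shown here, the earlier pair showed only that one exchange at this carbon raised the number; now a second, quite different group raises it further, so that acetoxymethyl gives the lowest number of the three groups, diethoxymethyl an intermediate one and 2-(4-nitrophenyl)ethenyl the highest, each step beyond the scatter. Nothing available accounts for this order, and the data offer no explanation for the rise.

The compounds shown do not separate the share of the ethenyl link from that of the 4-nitrophenyl ring, which a plain styryl group or a saturated 2-(4-nitrophenyl)ethyl chain at this carbon could address. They also leave open whether any group here can give a lower number than acetoxymethyl does, such as a hydroxymethyl, an aminomethyl or a carboxylic acid.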